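This account rests on a few compounds, and the source may have more. Where it says the series, first, only, none or still open, it means among the compounds named here.

Measured compounds in a functional assay on MCF7 cells (Homo sapiens) for cytotoxicity, read by sulforhodamine B assay, with a stated time of 48 h; on this read-out higher numbers stand for weaker inhibition of growth and lower numbers for stronger inhibition of growth:

compound 1 `Cc1nn(-c2ccccc2)c(Oc2ccc(-c3nc4cc(C(=O)O)ccc4[nH]3)cc2)c1/C=N/NC(N)=S` gives 18100 nM
compound 2 `Cc1nn(-c2ccccc2)c(Sc2ccc(-c3nc4cc(C(=O)O)ccc4[nH]3)cc2)c1/C=N/NC(N)=O` gives 13600 nM
compound 3 `Cc1nn(-c2ccccc2)c(Oc2ccc(-c3nc4cc(C(N)=O)ccc4[nH]3)cc2)c1/C=N/NC(N)=S` gives 9600 nM

Compound 1 and compound 3 share one core and differ at a single point: amino in place of hydroxy on a carbonyl carbon. This change gave a 1.9-fold lower number from compound 1 to compound 3 (0.28 log units; within the scatter), a step that the repeat scatter of this assay can account for on its own.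

Compound 2 carries a different core from compound 1; the two have the same atoms joined differently, and the difference between the two cores is not broken down here. Their values in this assay sit within the scatter of each other, as do the values of compound 2 and compound 3, so nothing is said here about an order among the three.

Compound 4 `Cc1nn(-c2ccccc2)c(Sc2ccc(-c3nc4cc(C(N)=O)ccc4[nH]3)cc2)c1/C=N/NC(N)=O` has not yet been measured. It stands to compound 2 as compound 3 stands to compound 1: amino in place of hydroxy on a carbonyl carbon. The place of the change is described in the same words in both pairs, so this is the same change made on the core of compound 2. It has been seen once, in the pair from compound 1 to compound 3, where it stayed inside the scatter.

From compound 2 to compound 4 a step of about a 1.7-fold lower number from compound 2 to compound 4 (0.23 log units; within the scatter) is expected in this assay, resting only on that one earlier pair and on compound 2 at 13600 nM. For the measured compounds named here, compound 4 is therefore estimated at 8000 nM, with a range from 3500 nM to 18000 nM, the width reflecting that the single precedent was itself within the scatter.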

Compound 4, concentration for 50% growth inhibition: 14900 nM
Estimate against measurement, compound 4: 1.9-fold (0.27 log units) below, and the stated range covers the measured number.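

In this assay, the change from carboxy to carbamoyl on the core of compound 2, with amino in place of hydroxy on a carbonyl carbon, gave a 1.1-fold higher number from compound 2 to compound 4 (0.04 log units; within the scatter). Set beside the earlier pair, the two steps do not differ by more than repeated measurements can account for: the same change on two cores in this assay, a 1.9-fold lower number (0.28 log units; within the scatter) from compound 1 to compound 3 and a 1.1-fold higher number (0.04 log units; within the scatter) from compound 2 to compound 4, 2.1-fold (0.32 log units) apart, within the scatter of two such steps

This shows that, across these two cores, the change has not produced a step that can be told from the repeat scatter, and that the steps on the two cores cannot be told apart from each other. It does not show that the change has no effect on growth inhibition, nor that it carries over between cores with a fixed size, since two small steps inside the scatter can support neither a shared effect nor one that depends on the core.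

Still open, as far as these compounds go, is whether a different group on the same carbonyl carbon, such as a methoxy group or a methylamino group, would give a step beyond the scatter on either core. Also open, from the compounds shown here alone, is whether amino in place of hydroxy would read the same way on any core other than these two.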